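Series notes: methyl on the anilino ring of compound 2

The source may hold more compounds than are shown below. What is called first, only, known or untested is meant among the compounds shown, and "the series" means these compounds.

Measured so far in an assay on isolated protein for inhibition of Nicotinamide phosphoribosyltransferase (Homo sapiens), read by WST assay, with stated times of 60 min, 5 min and 30 min, in the presence of a further agent that is not named here; on this read-out lower numbers stand for stronger inhibition and higher numbers for weaker inhibition:
compound 1, `O=C(/C=C/c1cccnc1)NCCCCCc1cccc(S(=O)(=O)Nc2ccccc2)c1`, gives 16.5 nM
compound 2, `O=C(/C=C/c1cccnc1)NCCCCCCc1cccc(S(=O)(=O)Nc2ccccc2)c1`, gives 10.5 nM

Compound 2 holds the lowest of the two numbers shown in this assay. Among the measured compounds shown here, the nearest is compound 1, whose number sits higher by a gap that stays within the scatter, so the two compounds cannot be set apart on these data; the pair differs in the length of the chain between the amide and the aromatic ring, and no counted step is given for it.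

Compound 3, `Cc1ccc(NS(=O)(=O)c2cccc(CCCCCCNC(=O)/C=C/c3cccnc3)c2)cc1`, has not yet been measured in this assay. It differs from compound 2 only in the following way: methyl in place of hydrogen on an aromatic carbon. For the measured compounds named here, no measured pair carries this change, so there is no step of this kind to lean on. With nothing in the two measured compounds pointing either way, the expectation is a step no larger than the scatter, in no fixed direction. Compound 3 is therefore estimated at 11 nM in this assay, with a range from 4 nM to 30 nM. That estimate for compound 3 amounts to an expected step of a 1.0-fold higher number from compound 2 to compound 3 (0.02 log units; within the scatter).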

Compound 3, half-maximal inhibitory concentration: 9.78 nM
Compound 3: middle estimate off by 1.1-fold (0.05 log units), on the high side; low and high end bracket the measured number.
By their numbers in this assay, from the lowest: compounds 3, 2 and 1 (each within the scatter of the next).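

Among the compounds shown here, replacing hydrogen with methyl on the anilino ring, para to a large group, gives in this assay a 1.1-fold lower number from compound 2 to compound 3 (0.03 log units; within the scatter), the first reading of any change to this ring. Within the two compounds compared, phenyl and 4-methylphenyl on the sulfamoyl group therefore cannot be told apart, and this carbon accepts one added carbon atom without a step beyond the scatter. No measurement shown here accounts for this result.

On these data alone, whether the same holds for a larger substituent on this carbon, such as a methoxy group, an amine or a carboxylic acid, stays open, as does the effect of a methyl on another carbon of this ring. The compounds shown also leave open whether the methyl would give a similar step on the shorter chain of compound 1, since only the longer chain of compound 2 carries this change here.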